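The source may report more compounds than this note shows. Statements on the series, on what has been measured and on what is new or still open speak of the compounds shown alone.

Working notes on the series. The shared core carries a 4-methoxybenzyl group on the nitrogen and a pendant aryl ring; compound 1 `COc1ccc(CN2C(=O)C(=O)c3cc(-c4cccc(OC)c4)ccc32)cc1` bears a 3-methoxyphenyl there and in a functional assay on HepG2 cells (Homo sapiens) for antiproliferative activity, read by MTT assay, with a stated time of 48 h (on this read-out lower numbers stand for stronger inhibition and higher numbers for weaker inhibition), compound 1 gives 1890 nM. Compound 2 `COc1ccc(CN2C(=O)C(=O)c3cc(-c4ccc(OC)c(OC)c4)ccc32)cc1` carries the 3,4-dimethoxyphenyl instead, and in this assay compound 2 reaches only the limit > 10000 nM. Compound 3 `COc1ccc(CN2C(=O)C(=O)c3cc(-c4ccc(C)cc4)ccc32)cc1` carries a 4-methylphenyl, and in this assay compound 3 likewise gives only the limit > 10000 nM; it therefore stands at the weak end of what is shown, alongside compound 2, and the step that the two limits leave unreadable from compound 2 to compound 3 cannot be read. Both steps away from compound 1, an at least 5.2-fold higher number from compound 1 to compound 2 (0.72 log units; beyond the scatter) and an at least 5.2-fold higher number from compound 1 to compound 3 (0.72 log units; beyond the scatter), are beyond the scatter, bounded by the limit of > 10000 nM in this assay, at which 2 of the 3 values shown sit.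

Compound 4 `COc1ccc(CN2C(=O)C(=O)c3cc(-c4ccc(C#N)cc4)ccc32)cc1` differs from compound 3 by cyano in place of methyl on an aromatic carbon. Among the measured compounds shown here, no measured step bears directly on this change; the only comparable moves, from compound 1 to compounds 2 and 3, both lost activity. The step that the limit leaves unreadable from compound 3 to compound 4 is therefore expected to stay small, and compound 4 is estimated at 12000 nM in this assay, between 3000 nM and 50000 nM.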

Compound 4, half-maximal inhibitory concentration: 890 nM
Beside the measured number, compound 4's estimate is 13-fold (1.13 log units) above it, and the stated range ends above it.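

On the pendant aryl ring, the aromatic carbon para to a large group can carry activity in this assay, which compounds 2 and 3 did not show: cyano in place of methyl gives an at least 11-fold lower number from compound 3 to compound 4 (1.05 log units; beyond the scatter). The 4-cyanophenyl ring also gives an at least 11-fold lower number from compound 2 to compound 4 (1.05 log units; beyond the scatter) and, against the 3-methoxyphenyl ring, a 2.1-fold lower number from compound 1 to compound 4 (0.33 log units; beyond the scatter), which makes compound 4 the most active of the four shown. The first two of these steps rest on limits for compound 3 and compound 2 rather than on numbers, so their full size stays unread: the limit of > 10000 nM in this assay, at which 2 of the 4 values shown sit.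

Going by these compounds, with one pair at this carbon, it remains open whether the gain belongs to cyano alone or would also appear with a carboxylic acid, an amine or a chlorine there. On these data alone, whether cyano keeps this effect on a ring that also carries methoxy remains open as well.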